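Working notes: from compound 3 to compound 4

The source may report more compounds than this note shows. Statements on the series, on what has been measured and on what is new or still open speak of the compounds shown alone.

In an ADME assay on blood (Rattus norvegicus) for metabolic stability, with a stated time of 2 h (on this read-out lower numbers stand for a less stable compound and higher numbers for a more stable compound), compound 1 (`CCC(=O)c1ccc(N(C)C(=O)CSc2nnc(CNc3ccccc3)n2CC)cc1`) gives 1.9% and compound 2 (`CCC(=O)c1ccc2oc(CS(=O)(=O)c3nnc(CNc4ccccc4)n3CC)nc2c1`) gives 44%, two values that lie far apart. Compound 3 (`CCn1c(CNc2ccccc2)nnc1SCc1nc2cc(F)ccc2o1`) has no place on this scale, as its entry reads "not determined" (no result reported) and no single number exists for it.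

The next structure is compound 4 (`CC/C(=N/O)c1ccc2oc(CSc3nnc(CNc4ccccc4)n3CC)nc2c1`). The change is a group of 5 heavy atoms (3 carbon, 1 nitrogen, 1 oxygen; no ring) in place of one fluorine atom, on an aromatic carbon: the fluoro leaves and the new group takes its place on an aromatic carbon, part of a fused or bridged system of two rings.

Without a number for compound 3, this step has no measured starting point in this assay. The working expectation is a step no larger than the scatter, in neither direction, and this cannot yet be tested. Compound 4 shares the fused system of two rings with compound 2, which gives 44%, while compound 1 lacks it, so compound 2 serves as the anchor, with wide uncertainty. For compound 4 the expected value is 42%, with an estimated range of 15% to 75%.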

Compound 4, percent of the compound remaining: 100%
Compound 4: the middle estimate sits 58 percentage points below what was measured; the whole stated range lies below it.
By their numbers in this assay, from the lowest: compound 1; then compound 2; then compound 4.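

Compound 3 has no number in this assay and compound 4 gives 100%, so no step can be read between them. The compounds shown leave open what the group replacing fluoro contributes to this read-out. No measured evidence bears on the result.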